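The source may report more compounds than this note shows. Statements on the series, on what has been measured and on what is new or still open speak of the compounds shown alone.

Measured in an ADME assay on WI-38 cells (Homo sapiens) for cytotoxicity, read by sulforhodamine B assay, with a stated time of 24 h; a lower number here means a stronger inhibitor, a higher number a weaker inhibitor:
Compound 1 `O=C1Nc2ccc(S(=O)(=O)N3CCOCC3)cc2/C1=N/c1ccc(Br)cc1`: 372000 nM
Compound 2 `O=C1Nc2ccc(S(=O)(=O)N3CCOCC3)cc2/C1=N/c1cccc(C(F)(F)F)c1`: 226000 nM

Going by the values given here, compound 2, at 226000 nM, stands level with compound 1, since the only measured step, a 1.6-fold lower number from compound 1 to compound 2 (0.22 log units; within the scatter), does not clear the scatter. Compound 3 `N/N=C1\C(=O)Nc2ccc(S(=O)(=O)N3CCOCC3)cc21` has amino in place of 3-(trifluoromethyl)phenyl on a double-bonded nitrogen. That measured step bears on this change only weakly. Among the compounds with values here, it exchanged 4-bromophenyl for 3-(trifluoromethyl)phenyl, and no measured compound lacks the aromatic ring on that nitrogen. The data therefore give no direction, and no shift beyond the scatter is expected in this assay, although the uncertainty is wide. The expected step is a 1.2-fold higher number from compound 2 to compound 3 (0.09 log units; within the scatter). For compound 3 the estimated value is 280000 nM, with an expected range from 90000 nM to 800000 nM.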

Compound 3, half-maximal inhibitory concentration: 391000 nM
Compound 3: the middle estimate sits 1.4-fold (0.15 log units) below what was measured; the measured number falls inside the stated range.
By their numbers in this assay, from the lowest: compounds 2, 1 and 3 (each within the scatter of the next).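

In this assay, going by these compounds alone, the aromatic ring on the double-bonded nitrogen can give way to a far smaller group with no step that clears the scatter: amino in place of 3-(trifluoromethyl)phenyl gives the first step below, and amino in place of 4-bromophenyl gives the second (a 1.7-fold higher number from compound 2 to compound 3 (0.24 log units; within the scatter); a 1.1-fold higher number from compound 1 to compound 3 (0.02 log units; within the scatter)). Within the data shown here, the earlier pair compared only two substituted phenyl groups, whereas compound 3 has no ring at this position, and all three compounds still cannot be told apart here. Nothing available accounts for this flat result.

The compounds shown leave open whether any group on this nitrogen can move the number beyond the scatter. A hydroxyl, a longer alkyl chain or a phenyl carrying a carboxylic acid at this position could test that.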